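Trimming Ethoxy to Methoxy on a Shared Core

The source may hold more compounds than are shown below. What is called first, only, known or untested is meant among the compounds shown, and "the series" means these compounds.

Measured so far in a functional assay on ZR-75-1 cells (Homo sapiens) for cytotoxicity, read by sulforhodamine B assay, with a stated time of 3 days; on this read-out higher numbers stand for an effect only at larger amounts of compound and lower numbers for an effect already at smaller amounts:
Compound 1 `COc1c(-c2occ(C)c2C(=O)O)ccc2c1CCCC2(C)C`: 41.4 uM
Compound 2 `CCOc1c(-c2occ(C)c2CO)ccc2c1CCCC2(C)C`: 14.3 uM

Of these two, compound 2 has the lower number at 14.3 uM, and compound 1 is higher at 41.4 uM, a gap beyond the usual scatter. The two differ in more than one place, so that gap does not isolate any single change.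

Compound 3 `COc1c(-c2occ(C)c2CO)ccc2c1CCCC2(C)C` has not yet been measured. It departs from compound 2 in one place: hydrogen in place of methyl on a saturated chain carbon bound to an oxygen on an aromatic ring, so ethoxy becomes methoxy. Among the compounds with values here, no measured pair shows this change alone, so the expectation starts from compound 2 at 14.3 uM. A slight rise in this assay is expected, but nothing beyond the scatter, and the estimated 1.2-fold higher number from compound 2 to compound 3 (0.08 log units; within the scatter) is small. For compound 3 the estimated value is 17 uM, with an expected range from 8 uM to 35 uM.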

Compound 3, concentration for half-maximal effect: 15 uM
Beside the measured number, compound 3's estimate is 1.1-fold (0.05 log units) above it; the range from low to high includes it.
By their numbers in this assay, from the lowest: compounds 2 and 3 (each within the scatter of the next); then compound 1.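

In this assay, trimming ethoxy to methoxy on the saturated chain carbon bound to an oxygen on an aromatic ring stays within the scatter (a 1.0-fold higher number from compound 2 to compound 3 (0.02 log units; within the scatter)), so on this core the methyl can go without a readable change in the number. Within the data shown here, compound 3 also gives the first single-place reading at a second site: hydroxymethyl in place of carboxy on an aromatic carbon (a 2.8-fold lower number from compound 1 to compound 3 (0.44 log units; beyond the scatter)) is a step beyond the scatter. Among these compounds, no earlier pair could isolate this change. Nothing at hand explains either result.

Going by these compounds, it remains open whether a longer chain such as propoxy would also leave the number unchanged, and whether an amine or an amide in place of hydroxymethyl would shift it. On these data alone, it is also open whether the carboxy step holds with ethoxy on the shared core.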